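Isoxazoline Ring Substituents and a Weak Chloride Channel Binder

A few compounds are considered here, and "the series" means these few. Any claim that something is new, unique, unknown or untested is made for them only; others in the source may bear on it.

Compound 3 `COc1cccc(COc2ccccc2C2=NOC(CO)C2)c1`: 115000 nM
Compound 2 `COc1cccc(COc2ccccc2C2=NOC(CCl)C2)c1`: 66000 nM
Compound 1 `COC(=O)C1CC(c2ccccc2OCc2ccc(OC)cc2)=NO1`: 50000 nM

Of the compounds shown here, three have been measured in an assay with Cystic fibrosis transmembrane conductance regulator (Rattus norvegicus) as the target; on this read-out lower numbers stand for tighter binding and higher numbers for weaker binding. Compound 3 gives the highest of the three numbers, 115000 nM; compound 2 is nearest, at 66000 nM, and the step of a 1.7-fold higher number from compound 2 to compound 3 (0.24 log units; within the scatter) is within the scatter. Among the compounds with values here, compound 1, the only one bearing a methoxycarbonyl group on the saturated ring carbon, lies furthest, at 50000 nM, beyond the scatter from compound 3.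

Compound 4 `COC(=O)C1CC(c2ccccc2OCc2cccc(OC)c2)=NO1` is not yet measured. It differs from compound 3 by methoxycarbonyl in place of hydroxymethyl on a saturated ring carbon. Within the data shown here, no measured step bears on this exact change, since the chloro-to-hydroxy step between compound 2 and compound 3 concerns a different group. Compound 1 offers the only point of reference for a methoxycarbonyl group, and its value sits lower than that of compound 3.

Compound 4 is therefore expected to give a number near that of compound 1, which means the expected step of a 1.9-fold lower number from compound 3 to compound 4 (0.28 log units; within the scatter). The estimate for compound 4 in this assay is 60000 nM, with a range from 25000 nM to 150000 nM.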

Compound 4, dissociation constant: 110000 nM
For compound 4 the middle estimate is 1.8-fold (0.26 log units) below the measured one, and the stated range covers the measured number.
By their numbers in this assay, from the lowest: compounds 1, 2, 4 and 3 (each within the scatter of the next, the first and the last beyond it).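

In this assay, the change to methoxycarbonyl in place of hydroxymethyl on this saturated ring carbon gives a 1.0-fold lower number from compound 3 to compound 4 (0.02 log units; within the scatter) and the change to methoxycarbonyl in place of chloromethyl gives a 1.7-fold higher number from compound 2 to compound 4 (0.22 log units; within the scatter) so these three groups cannot be told apart here. Within the data shown here, a methoxycarbonyl group at this position therefore does not by itself go with the number of compound 1, as the change to 3-methoxyphenyl in place of 4-methoxyphenyl gives a 2.2-fold higher number from compound 1 to compound 4 (0.34 log units; beyond the scatter) and is the only new step beyond the scatter. No measurement shown accounts for these numbers.

From the compounds shown here alone, whether an amine or a carboxylic acid on this ring carbon would leave the number unchanged remains open. So does whether the step from 4-methoxyphenyl to 3-methoxyphenyl would recur with hydroxymethyl or chloromethyl on that carbon.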